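This account rests on a few compounds, and the source may have more. Where it says the series, first, only, none or still open, it means among the compounds named here.

Measured compounds:
compound 1 `C#CCSc1nc(Nc2ccccc2Cl)c2ccncc2n1` — > 80000 nM
compound 2 `C#CCSc1nc(Nc2ccc(Cl)cc2Cl)c2ccncc2n1` — 30400 nM
compound 3 `C#CCSc1nc(Nc2ccccc2OC)c2ccncc2n1` — > 80000 nM

In a functional assay on PC-3 cells (Homo sapiens) for inhibition, read by MTT assay, with a stated time of 72 h (on this read-out lower numbers stand for stronger inhibition and higher numbers for weaker inhibition), compound 1 gives > 80000 nM, which is a limit of the assay and not a number. Compound 3 gives > 80000 nM, again a limit. Among the compounds with values here, compound 2 gives 30400 nM in this assay, the only number in the set. Two of the three values sit at the same place, described by the limit of > 80000 nM in this assay, at which 2 of the 3 values shown sit. The step of an at least 2.6-fold lower number from compound 1 to compound 2 (0.42 log units; beyond the scatter) is beyond the scatter and runs toward lower numbers, while the step that the two limits leave unreadable from compound 1 to compound 3 cannot be read, since both ends are limits.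

Compound 4 `C#CCSc1nc(Nc2ccc(O)cc2)c2ccncc2n1` differs from compound 1 in one place: 4-hydroxyphenyl in place of 2-chlorophenyl on a nitrogen on an aromatic ring. Neither measured step covers this change. Within the data shown here, the only readable step adds a chloro and lowers the number; the exchange of chloro for methoxy gives no readable step. With compound 1 itself at a limit, the expectation for compound 4 is a value near the limit, estimated at 60000 nM with a range from 15000 nM to 150000 nM. The expected step of an at least 1.3-fold lower number from compound 1 to compound 4 (0.12 log units; that floor lies within the scatter) is accordingly small, and a further limit rather than a number is thought likely for compound 4.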

Compound 4, half-maximal inhibitory concentration: > 80000 nM
Compound 4: a limit, no number (the forecaster's own chance of this, stated with the estimate: 60%); at least 1.3-fold (0.12 log units) between middle value and limit.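

In this assay compound 4 gives > 80000 nM, a limit and not a number. Within the data shown here, compound 1 also stands at a limit, and the step from compound 1 to compound 4 cannot be read, leaving no new step. The compounds shown leave open whether 4-hydroxyphenyl and 2-chlorophenyl differ at all in this assay.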